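The source may report more compounds than this note shows. Statements on the series, on what has been measured and on what is new or still open speak of the compounds shown alone.

- Compound 1 `CC(=O)NCC(=O)N(C)c1ccc(Cl)cc1C(=O)c1ccccc1Cl`: 2.3 mg/kg
- Compound 2 `CCN(CC)CC(=O)NCC(=O)N(C)c1ccc(Cl)cc1C(=O)c1ccccc1Cl`: 2.2 mg/kg

In a functional assay on the whole organism for antagonist activity, with Mus musculus as the target (on this read-out higher numbers stand for an effect only at larger amounts of compound and lower numbers for an effect already at smaller amounts), compound 1 gives 2.3 mg/kg and compound 2 gives 2.2 mg/kg. With only these two numbers, compound 2 stands level with compound 1, since the two lie within the scatter of each other.

The next compound to be tested is compound 3 `CN(C(=O)CNC(=O)CN1CCN(c2ccccc2)CC1)c1ccc(Cl)cc1C(=O)c1ccccc1Cl`. It keeps everything in compound 2 except one group: 4-phenylpiperazin-1-yl in place of diethylamino on a saturated chain carbon bound to a carbonyl carbon. Here 4-phenylpiperazin-1-yl takes the place of diethylamino on a saturated chain carbon bound to a carbonyl carbon.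

Among the measured compounds shown here, only one measured step bears on this change. Putting diethylamino in place of hydrogen at that same place gave a 1.0-fold lower number from compound 1 to compound 2 (0.02 log units; within the scatter), which is within the scatter. That single step offers no reason to expect a shift in either direction in this assay. For the measured compounds named here, still, no measured compound carries a ring on that chain carbon, so the evidence is thin and the range must stay wide.

The expected step is a 1.4-fold higher number from compound 2 to compound 3 (0.13 log units; within the scatter), which is nothing beyond the scatter.

For compound 3 the estimated value is 3 mg/kg, with an expected range from 1 mg/kg to 9 mg/kg.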

Compound 3, dose for half-maximal effect: 75 mg/kg
Compound 3: the middle estimate sits 25-fold (1.40 log units) below what was measured, and the stated range ends below it.
By their numbers in this assay, from the lowest: compounds 2 and 1 (each within the scatter of the next); then compound 3.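

In this assay, 4-phenylpiperazin-1-yl in place of diethylamino on the saturated chain carbon bound to a carbonyl carbon gives a 34-fold higher number from compound 2 to compound 3 (1.53 log units; beyond the scatter) and so a far larger dose for the half-maximal effect. The same group in place of hydrogen gives a 33-fold higher number from compound 1 to compound 3 (1.51 log units; beyond the scatter) and shows that this place is not indifferent to what it carries, even though hydrogen and diethylamino could not be told apart there. The entering group has 12 heavy atoms and two rings, against 5 heavy atoms and no ring for diethylamino, but no measurement here explains the rise in the number.

The compounds shown cannot separate the part played by the phenyl ring from that of the piperazine ring, a question that 4-methylpiperazin-1-yl or an unsubstituted piperazine at the same place could address. They also leave open whether simpler ring amines such as piperidin-1-yl or morpholin-4-yl would stay level with diethylamino or follow 4-phenylpiperazin-1-yl toward larger doses.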